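The source may hold more compounds than are shown below. What is called first, only, known or untested is meant among the compounds shown, and "the series" means these compounds.

Compound 1, `O=C(/C=C\c1cccc([N+](=O)[O-])c1)N1N=C(c2ccncc2)OC1c1c[nH]c2ccccc12`: in an ADME assay on HeLa cells (Homo sapiens) for cytotoxicity, read by MTT assay, with a stated time of 72 h (a higher number here means a weaker inhibitor of growth, a lower number a stronger inhibitor of growth), compound 1 gives > 30 ug/mL, which is a limit of the assay and not a number.
Compound 2, `O=C(/C=C\c1ccc([N+](=O)[O-])cc1)N1N=C(c2ccncc2)OC1c1c[nH]c2ccccc12`: in this assay compound 2 gives > 30 ug/mL, again a limit rather than a number.
Compound 3, `O=C(/C=C\c1cccc(Cl)c1)N1N=C(c2ccncc2)OC1c1c[nH]c2ccccc12`: in this assay compound 3 gives > 30 ug/mL, likewise a limit.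

Going by the values given here, compound 2 therefore stands at the same limit as every other measured compound, (the limit of > 30 ug/mL in this assay, at which 3 of the 3 values shown sit), so no compound can be ranked against another. The step that the two limits leave unreadable from compound 1 to compound 2 and the step that the two limits leave unreadable from compound 2 to compound 3 cannot be read for size, and the same holds for a step that the two limits leave unreadable from compound 1 to compound 3. The new compound is compound 4, `O=C(/C=C\c1ccc(Br)cc1)N1N=C(c2ccncc2)OC1c1c[nH]c2ccccc12`. It differs from compound 2 by bromo in place of nitro on an aromatic carbon. Among the compounds with values here, none of the measured steps gives a readable size, so no direction can be drawn from them in this assay; the only guide is that every neighbour sits at the limit. The expectation for compound 4 is therefore a value near or at that limit, with the step that the limit leaves unreadable from compound 2 to compound 4 expected to be none beyond the scatter. Compound 4 is estimated at 40 ug/mL, ranging from 15 ug/mL to 100 ug/mL.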

Compound 4, concentration for 50% growth inhibition: > 30 ug/mL
Compound 4 ended at the assay's limit; the forecaster's own chance of this, stated with the estimate: 75%; the middle value lies beyond the limit too.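

Compound 4 stands at a limit of the assay, just as compound 1, compound 2 and compound 3 do, so none of the new steps can be read for size: the limit of > 30 ug/mL in this assay, at which 4 of the 4 values shown sit.
In this assay it remains open how strongly any of these compounds inhibits growth, and whether the nitro, chloro and bromo groups differ at all.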